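1H-indol-3-yl in place of phenyl on a shared core

The source may report more compounds than this note shows. Statements on the series, on what has been measured and on what is new or still open speak of the compounds shown alone.

Of the compounds shown here, three have been tested in an assay on isolated protein for inhibition of protein deacetylase HDAC6 (Homo sapiens), read by fluorescence, with stated times of 3 h and 60 min; on this read-out higher numbers stand for weaker inhibition and lower numbers for stronger inhibition. Compound 1 `Nc1ccccc1NC(=O)c1ccc(CNC2=NC(=O)C(Cc3c[nH]c4ccccc34)N2)cc1` is reported only as a limit of the assay, > 20000 nM. Compound 2 `CC(C)(C)OC(=O)N1C(NCc2ccc(C(=O)Nc3ccccc3N)cc2)=NC(=O)C1Cc1c[nH]c2ccccc12` likewise reaches only a limit of the assay, giving > 20000 nM in this assay. Between them lies a step that the two limits leave unreadable from compound 1 to compound 2, and the size of that step cannot be read because both ends are limits. Compound 3 `CC(=O)N1C(NCc2ccc(C(=O)Nc3ccccc3N)cc2)=NC(=O)C1Cc1ccccc1` also stands only at a limit of the assay, > 20000 nM; nothing more than that is known of its position, and all that the measurements show is the limit of > 20000 nM in this assay, at which 3 of the 3 values shown sit.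

The next compound, compound 4 `CC(=O)N1C(NCc2ccc(C(=O)Nc3ccccc3N)cc2)=NC(=O)C1Cc1c[nH]c2ccccc12`, differs from compound 3 by 1H-indol-3-yl in place of phenyl on a saturated chain carbon bound to a saturated ring carbon. For the measured compounds named here, no measured step bears directly on this change, since the only step between measured compounds concerns a tert-butoxycarbonyl group on an amine nitrogen in a ring and is itself unreadable. What can be said is that compound 1, which carries the same 1H-indol-3-yl group, and compound 3, which carries the phenyl, both sit at the limit. The step that the limit leaves unreadable from compound 3 to compound 4 is therefore expected to show nothing beyond the scatter, and compound 4 is estimated at 30000 nM, within 8000 nM to 120000 nM.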

Compound 4, half-maximal inhibitory concentration: > 20000 nM
Compound 4 gave a limit, no number; the forecaster's own chance of this, stated with the estimate: 85%; the middle value is on the limit's open side.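

Compound 4 reaches only a limit of the assay, as do compound 1, compound 2 and compound 3, so none of the steps from these compounds to compound 4 can be read: the limit of > 20000 nM in this assay, at which 4 of the 4 values shown sit.

The compounds shown leave open how large any of these changes is, and whether any compound on the shared core gives a number rather than a limit.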